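Swapping the aryl group on the triazole in a spiro series

The compounds below may be only part of what the source reports. "The series", "measured", "known", "first", "only" and "open" are said of these compounds alone.

Three compounds share one spiro core and differ only in the aryl group on the triazole nitrogen. Compound 1 `N#CC1=C(N)Oc2c(c3nc4ccccc4nc3c3ccccc23)C12C(=O)N(Cc1cnnn1-c1cccc(Br)c1)c1ccccc12` was tested in a functional assay on HepG2 cells (Homo sapiens) for antiproliferative activity, read by MTT assay, with a stated time of 48 h; a higher number here means a weaker inhibitor, a lower number a stronger inhibitor. In this assay compound 1 gives only a limit, > 50000 nM. Compound 2 `Cc1ccc(Cl)cc1-n1nncc1CN1C(=O)C2(C(C#N)=C(N)Oc3c2c2nc4ccccc4nc2c2ccccc32)c2ccccc21` likewise gives only a limit, > 50000 nM. The step that the two limits leave unreadable from compound 1 to compound 2 therefore cannot be read. Compound 3 `N#CC1=C(N)Oc2c(N)cc3nc4ccccc4nc3c2C12C(=O)N(Cc1cnnn1-c1ccc(F)cc1)c1ccccc12` also sits at a limit, > 50000 nM; this is where compound 3 stands, with no exact number known.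

Compound 4 `N#CC1=C(N)Oc2c(N)cc3nc4ccccc4nc3c2C12C(=O)N(Cc1cnnn1-c1ccc(Cl)cc1Cl)c1ccccc12` differs from compound 3 in one place: 2,4-dichlorophenyl in place of 4-fluorophenyl on an aromatic nitrogen. For the measured compounds named here, the only measured step with a change at the same position is a step that the two limits leave unreadable from compound 1 to compound 2, and its size is unreadable. All guidance comes from the limit of > 50000 nM in this assay, at which 3 of the 3 values shown sit, where every measured value rests.

With no readable step, compound 4 is expected to stay at the same limit, an estimated 80000 nM (range 30000 nM to 300000 nM), meaning an expected step that the limit leaves unreadable from compound 3 to compound 4.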

Compound 4, half-maximal inhibitory concentration: > 50000 nM
Compound 4 ended at the assay's limit; the forecaster's own chance of this, stated with the estimate: 85%; the middle value is on the limit's open side.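

Compound 3 and compound 4 both end at a limit rather than a number, so the step between them cannot be read, and the same holds for compound 1 and compound 2. All four compounds rest at one place: the limit of > 50000 nM in this assay, at which 4 of the 4 values shown sit. On these data alone, how strongly any of them acts on these cells, and whether the aryl group on the triazole matters at all, stays open.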